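The source may hold more compounds than are shown below. What is called first, only, known or untested is meant among the compounds shown, and "the series" means these compounds.

Four compounds built on a shared core are in view: compound 1 (`CC(C)c1ccc(C(=O)NC(=O)c2ccccc2O)cc1`), compound 2 (`O=C(NC(=O)c1ccccc1O)c1ccc(F)cc1`), compound 3 (`O=C(NC(=O)c1ccccc1O)c1ccc(OC(F)(F)F)cc1`) and compound 4 (`CCCCOc1ccc(C(=O)NC(=O)c2ccccc2O)cc1`). In an ADME assay on L6 cells (Rattus norvegicus) for cytotoxicity, read by resazurin assay, with a stated time of 72 h (a higher number here means a weaker inhibitor, a lower number a stronger inhibitor), compound 1 gives 19 ug/mL, compound 2 gives 38 ug/mL and compound 3 gives 84 ug/mL. Compound 3 therefore holds the highest number of the three. Two measured steps lead to it, both modest and beyond the scatter: a 4.4-fold higher number from compound 1 to compound 3 (0.65 log units; beyond the scatter) and a 2.2-fold higher number from compound 2 to compound 3 (0.34 log units; beyond the scatter). The remaining step, a 2.0-fold higher number from compound 1 to compound 2 (0.30 log units; within the scatter), stays within the scatter.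

Compound 4 is reached from compound 3 by placing butyl in place of trifluoromethyl on an oxygen on an aromatic ring. Going by the values given here, no measured step makes this exact change, so any expectation is a loose one. The closest guide is compound 1, whose isopropyl group, like butyl, holds no fluorine. The measured step to go by is a 4.4-fold higher number from compound 1 to compound 3 (0.65 log units; beyond the scatter). Most of that modest step is therefore expected to be undone, moving the number down in this assay. The step expected is a 2.8-fold lower number from compound 3 to compound 4 (0.45 log units; beyond the scatter). For compound 4 the estimated value is 30 ug/mL, with an expected range from 10 ug/mL to 70 ug/mL.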

Compound 4, half-maximal inhibitory concentration: 13 ug/mL
For compound 4 the middle estimate is 2.3-fold (0.36 log units) above the measured one; low and high end bracket the measured number.
By their numbers in this assay, from the lowest: compounds 4, 1 and 2 (each within the scatter of the next, the first and the last beyond it); then compound 3.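

In this assay, going by these compounds alone, the change on the oxygen alone gives a 6.5-fold lower number from compound 3 to compound 4 (0.81 log units; beyond the scatter) while the oxygen itself stays in place, so the group carried by that oxygen moves the number, something the earlier steps could not show because each replaced the whole group on the aromatic carbon. Butoxy also separates from fluoro, with a 2.9-fold lower number from compound 2 to compound 4 (0.47 log units; beyond the scatter) in the same assay, which compound 1 did not do, yet against isopropyl it gives a 1.5-fold lower number from compound 1 to compound 4 (0.16 log units; within the scatter) and so cannot be placed in any order with it, leaving compound 3 alone at the high end among these four. Nothing available bears on the reason for the step from trifluoromethyl to butyl.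

The compounds shown leave open whether the fluorine atoms or the carbon chain account for this step, a question that a plain methyl on the same oxygen or a longer chain such as hexyl would help to separate. They also leave open how an amine or a carboxylic acid carried at the end of that chain would read in this assay on the shared core.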